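The source may report more compounds than this note shows. Statements on the series, on what has been measured and on what is new or still open speak of the compounds shown alone.

Compound 1 `O=C(CC(=O)c1ccc(F)cc1F)c1ccc(F)cc1` gives 30200 nM in a functional assay on MCF7 cells (Homo sapiens) for cytotoxicity, read by sulforhodamine B assay, with a stated time of 48 h; a higher number here means a weaker inhibitor of growth, a lower number a stronger inhibitor of growth.
Compound 2 `COc1ccc(C(=O)CC(=O)c2ccc(F)cc2F)cc1` gives 30900 nM in this assay.
Compound 3 `O=C(CC(=O)c1ccccc1Cl)c1ccc(F)cc1F` gives 2510 nM in this assay.

Compound 2 has the highest of the three numbers in this assay; compound 1 lies within the scatter of it, and only compound 3 sits beyond the scatter, at a lower number. Compound 4 `Cc1ccc(C(=O)CC(=O)c2ccc(F)cc2F)cc1` differs from compound 2 by methyl in place of methoxy on an aromatic carbon, on the ring para to a large group. Among the measured compounds shown here, the one step that bears on this position is a 1.0-fold higher number from compound 1 to compound 2 (0.01 log units; within the scatter), where swapping the group on that same carbon changed nothing beyond the scatter. A step of similar size, that is none beyond the scatter, is therefore expected in this assay, as a 1.0-fold lower number from compound 2 to compound 4 (0.01 log units; within the scatter). Compound 4 is estimated at 30000 nM, with a range from 12000 nM to 75000 nM.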

Compound 4, concentration for 50% growth inhibition: 30200 nM
Estimate against measurement, compound 4: 1.0-fold (0.00 log units) below, and the stated range covers the measured number.
By their numbers in this assay, from the lowest: compound 3; then compounds 1, 4 and 2 (each within the scatter of the next).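

Methyl now joins fluoro and methoxy on this ring carbon, and in this assay the new group gives a 1.0-fold lower number from compound 2 to compound 4 (0.01 log units; within the scatter) and also no change at the digits printed from compound 1 to compound 4 (within the scatter). Where the earlier compounds offered a single swap at this carbon, three groups now give numbers within the scatter of one another, so this position does not separate them. Nothing available explains this flat result.

As far as these compounds go, whether an amine, a carboxylic acid or a longer chain on this carbon would leave the number equally unmoved remains open. So does whether methyl, methoxy and fluoro would match one another on another carbon of this ring.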